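Expected Effect of Replacing 4-Bromophenyl in Compound 1

The source may hold more compounds than are shown below. What is called first, only, known or untested is meant among the compounds shown, and "the series" means these compounds.

Compound 1 `O=C(CSc1nnc(-c2ccncc2)o1)N/N=C/c1ccc(Br)cc1` gives 24500 nM in a functional assay on BGC-823 cells (Homo sapiens) for cytotoxicity, read by MTT assay, with a stated time of 48 h; on this read-out lower numbers stand for stronger inhibition and higher numbers for weaker inhibition.
Compound 2 `O=C(CSc1nnc(-c2ccncc2)o1)N/N=C/c1ccccc1O` gives 6160 nM in this assay.

Compound 1 stands highest of the two measured numbers; its nearest neighbour is compound 2, reached by a 4.0-fold lower number from compound 1 to compound 2 (0.60 log units; beyond the scatter). Compound 3 `O=C(CSc1nnc(-c2ccncc2)o1)N/N=C/c1cc(Br)cc(Br)c1O` differs from compound 1 as follows: 3,5-dibromo-2-hydroxyphenyl in place of 4-bromophenyl on a carbon with a double bond to nitrogen. Within the data shown here, the only measured step that bears on this change is the one in which 2-hydroxyphenyl replaced 4-bromophenyl, a 4.0-fold lower number from compound 1 to compound 2 (0.60 log units; beyond the scatter), a modest lowering beyond the scatter. For compound 3 the same lowering is therefore expected, with added uncertainty from the two bromines: a 4.5-fold lower number from compound 1 to compound 3 (0.65 log units; beyond the scatter). Compound 3 is estimated at 5500 nM, within 1500 nM to 20000 nM.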

Compound 3, half-maximal inhibitory concentration: 9610 nM
Compound 3: middle estimate off by 1.7-fold (0.24 log units), on the low side, and the stated range covers the measured number.
By their numbers in this assay, from the lowest: compounds 2 and 3 (each within the scatter of the next); then compound 1.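

In this assay, 3,5-dibromo-2-hydroxyphenyl in place of 4-bromophenyl on the carbon with a double bond to nitrogen gives a 2.5-fold lower number from compound 1 to compound 3 (0.41 log units; beyond the scatter), so a second replacement at this position also lowers the number beyond the scatter. With 3,5-dibromo-2-hydroxyphenyl in place of 2-hydroxyphenyl the result is a 1.6-fold higher number from compound 2 to compound 3 (0.19 log units; within the scatter), so the two added bromines leave no readable difference. Nothing measured here gives a reason for either step. The compounds shown leave open whether a methoxy group or an amine in place of the hydroxyl would keep the lower number.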